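Chloro in place of trifluoromethyl: expected cell toxicity

The compounds below may be only part of what the source reports. "The series", "measured", "known", "first", "only" and "open" are said of these compounds alone.

Compound 1 `COc1cc2cc(Oc3ccc(NC(=O)Nc4cccc(C(F)(F)F)c4)cc3)c(C)nc2cc1OC`: 48600 nM
Compound 2 `COc1cc2cc(Oc3ccc(NC(=O)Nc4ccc(Cl)c(C(F)(F)F)c4)cc3)c(C)nc2cc1OC`: 25200 nM

For the measured compounds named here, in a functional assay on CAKI-1 cells (Homo sapiens) for inhibition, read by sulforhodamine B assay, with a stated time of 48 h (on this read-out lower numbers stand for higher toxicity in this test and higher numbers for lower toxicity in this test), compound 2 gives 25200 nM, the lowest of the two numbers; its only neighbour is compound 1, and the step of a 1.9-fold lower number from compound 1 to compound 2 (0.29 log units; within the scatter) lies within the scatter. Compound 3 `COc1cc2cc(Oc3ccc(NC(=O)Nc4ccc(Cl)c(Cl)c4)cc3)c(C)nc2cc1OC` is not yet measured. It differs from compound 2 by chloro in place of trifluoromethyl on an aromatic carbon. Going by the values given here, no measured step covers this change, and the one measured step was within the scatter, so no shift beyond the scatter is expected in this assay. Compound 3 is therefore estimated at 28000 nM, range 10000 nM to 80000 nM, an expected step of a 1.1-fold higher number from compound 2 to compound 3 (0.05 log units; within the scatter).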

Compound 3, concentration lethal to 50% of the cells: 49500 nM
Compound 3: middle estimate off by 1.8-fold (0.25 log units), on the low side, within the range that was stated.
By their numbers in this assay, from the lowest: compounds 2, 1 and 3 (each within the scatter of the next).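

In this assay, chloro in place of trifluoromethyl on this aromatic carbon gives a step (a 2.0-fold higher number from compound 2 to compound 3 (0.29 log units; within the scatter)) that stays within the scatter, so this exchange does not separate the two groups here. The wider change from 3-(trifluoromethyl)phenyl to 3,4-dichlorophenyl (a 1.0-fold higher number from compound 1 to compound 3 (0.01 log units; within the scatter)) likewise stays within the scatter, and all three compounds remain indistinguishable in this test. Nothing available explains these numbers. As far as these compounds go, whether a methoxy group, an amine or a carboxylic acid at this position would shift the number beyond the scatter remains open.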